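A few compounds are considered here, and "the series" means these few. Any claim that something is new, unique, unknown or untested is made for them only; others in the source may bear on it.

Measured compounds:
Compound 1, `Cc1ccc(-c2cc(-c3ccoc3)cc(-c3ccc(Cl)s3)n2)cc1`, gives 1170 nM in a functional assay on HCT-15 cells (Homo sapiens) for cytotoxicity, read by ELISA, with a stated time of 4 days; on this read-out lower numbers stand for stronger inhibition and higher numbers for weaker inhibition.
Compound 2, `Clc1cccc(-c2cc(-c3ccoc3)cc(-c3ccc(Cl)s3)n2)c1`, gives 950 nM in this assay.
Compound 3, `Cc1ccc(-c2cc(-c3ccc(Cl)o3)cc(-c3ccc(Cl)s3)n2)cc1`, reaches only the limit of > 50000 nM in this assay.

The change 3-chlorophenyl in place of 4-methylphenyl on an aromatic carbon made a step of a 1.2-fold lower number from compound 1 to compound 2 (0.09 log units; within the scatter). The two cores differ by 5-chlorofuran-2-yl in place of furan-3-yl on an aromatic carbon, a step of an at least 42-fold higher number from compound 1 to compound 3 (1.63 log units; beyond the scatter), where compound 3 sits at the limit (the limit of > 50000 nM in this assay, at which 1 of the 3 values shown sits).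

Compound 4, `Clc1cccc(-c2cc(-c3ccc(Cl)o3)cc(-c3ccc(Cl)s3)n2)c1`, has not yet been measured. It differs from compound 3 by 3-chlorophenyl in place of 4-methylphenyl on an aromatic carbon; this is the same kind of change as from compound 1 to compound 2, though there the place is meta to a furan-3-yl group rather than a 5-chlorofuran-2-yl group. Resting on the small step of a 1.2-fold lower number from compound 1 to compound 2 (0.09 log units; within the scatter), compound 4 is expected to move only by a step that the limit leaves unreadable from compound 3 to compound 4. Compound 4 is thus estimated at 60000 nM, likely again a limit.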

Compound 4, half-maximal inhibitory concentration: > 50000 nM
Compound 4 gave a limit, no number; the forecaster's own chance of this, stated with the estimate: 80%; the middle value lies beyond the limit too.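

In this assay the change to 5-chlorofuran-2-yl from furan-3-yl carried over to the core with the 3-chlorophenyl group, giving an at least 52-fold higher number from compound 2 to compound 4 (1.72 log units; beyond the scatter). Set beside the earlier step, the direction holds on both cores, but the size cannot be compared: the same change on two cores in this assay, an at least 42-fold higher number (1.63 log units; beyond the scatter) from compound 1 to compound 3 and an at least 52-fold higher number (1.72 log units; beyond the scatter) from compound 2 to compound 4; the limit leaves it open whether they differ Compound 4 stands at > 50000 nM, a limit and not a number, and the step for 3-chlorophenyl in place of 4-methylphenyl on this core cannot be read.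

The compounds shown leave open whether the large step follows from the chlorine or from the point at which the furan is attached. On these data alone, a plain furan-2-yl group would separate the two, and an amine or a carboxylic acid on the furan also remains open in this assay.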